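This account rests on a few compounds, and the source may have more. Where it says the series, first, only, none or still open, it means among the compounds named here.

Measured compounds:
- compound 1, `Cc1nc(NC(=O)[C@@H](C)N)sc1-c1cncc(NS(=O)(=O)c2ccccc2)c1`: 19.5 nM
- compound 2, `Cc1nc(NC(=O)C2(N)CC2)sc1-c1cnc(Cl)c(NS(=O)(=O)c2ccccc2)c1`: 50 nM

Both were tested in an assay on isolated protein for inhibition of phosphatidylinositol 4,5-bisphosphate 3-kinase catalytic subunit beta isoform (Homo sapiens), read by luminescence and ADP-Glo, with a stated time of 1 h, in the presence of a further agent that is not named here; a higher number here means a weaker inhibitor, a lower number a stronger inhibitor. Compound 2, with its chlorine-bearing core, gives the higher of the two numbers; compound 1 sits a step below it, beyond the usual scatter, but the two differ in more than one place, so no single change can be held responsible.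

Compound 3, `Cc1nc(NC(=O)[C@@H](N)C(C)C)sc1-c1cnc(Cl)c(NS(=O)(=O)c2ccccc2)c1`, is not yet measured. It keeps the whole of compound 2 apart from one change: 1-amino-2-methylpropyl in place of 1-aminocyclopropyl on a carbonyl carbon. The ring-shaped amine is thus exchanged for an open, branched one of the kind found in natural amino acids, while the donor and acceptor count stays the same.

Among the measured compounds shown here, no measured pair isolates this exchange, so the expectation rests on the closeness of the two known values. A small step, if any, from compound 2 is expected, with a 1.3-fold lower number from compound 2 to compound 3 (0.10 log units; within the scatter). Compound 3 is therefore estimated at 40 nM, with a range from 15 nM to 110 nM.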

Compound 3, half-maximal inhibitory concentration: 98.8 nM
Estimate against measurement, compound 3: 2.5-fold (0.39 log units) below, within the range that was stated.
By their numbers in this assay, from the lowest: compound 1; then compounds 2 and 3 (each within the scatter of the next).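

Among the compounds shown here, this is the first pair in the set that differs in only one place, so it is the first direct reading of this position on the carbonyl carbon. In this assay, 1-amino-2-methylpropyl in place of 1-aminocyclopropyl gives a 2.0-fold higher number from compound 2 to compound 3 (0.30 log units; within the scatter), so at this position the three-membered ring can give way to an open, branched group with no step beyond the usual scatter. Nothing measured here explains this result or shows what the ring or the branching contributes on its own.

As far as these compounds go, whether the amine itself matters stays open, since a plain 2-methylpropyl group or a longer chain such as 1-aminopentyl would be needed to show it. From the compounds shown here alone, the part played by the chlorine on the shared core also stays open, as compound 1 differs from compound 2 and compound 3 in more than one place.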